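Adding a nitro group to compound 3

A few compounds are considered here, and "the series" means these few. Any claim that something is new, unique, unknown or untested is made for them only; others in the source may bear on it.

In a functional assay on MCF7 cells (Homo sapiens) for antiproliferative activity, read by MTT assay, with a stated time of 24 h (a higher number here means a weaker inhibitor, a lower number a stronger inhibitor), compound 3 (`O=S(=O)(c1ccccc1)n1c(-c2cn(-c3ccccc3)nc2-c2ccc(F)cc2)nc2ccccc21`) gives 690 nM. Compound 1 (`Cc1ccc(-c2nn(-c3ccccc3)cc2-c2nc3ccccc3n2S(=O)(=O)c2ccccc2)cc1`) gives 830 nM, and compound 2 (`Cc1ccc(-c2nn(-c3ccccc3)cc2-c2nc3ccccc3n2S(=O)(=O)c2ccc(F)cc2)cc1`) gives 5270 nM. Compound 4 (`O=[N+]([O-])c1ccc(S(=O)(=O)n2c(-c3cn(-c4ccccc4)nc3-c3ccc(F)cc3)nc3ccccc32)cc1`) has not yet been measured. It is compound 3 with a single change on the phenylsulfonyl group, nitro in place of hydrogen on an aromatic carbon.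

Among the measured compounds shown here, two measured steps bear on this change. Fluoro in place of methyl, away from the phenylsulfonyl group, gives a 1.2-fold lower number from compound 1 to compound 3 (0.08 log units; within the scatter), so compound 3 can reasonably stand in for compound 1 as a starting point. Fluoro in place of hydrogen on the phenylsulfonyl group gives a 6.3-fold higher number from compound 1 to compound 2 (0.80 log units; beyond the scatter), and this is the closest precedent. For the measured compounds named here, no nitro compound has been measured, so this single fluoro step is thin evidence, and a higher number is expected only tentatively. The estimated change, somewhat smaller than the fluoro precedent, is a 2.9-fold higher number from compound 3 to compound 4 (0.46 log units; beyond the scatter). For compound 4 the estimated value is 2000 nM, with an expected range of 450 nM to 7500 nM.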

Compound 4, half-maximal inhibitory concentration: 1370 nM
Beside the measured number, compound 4's estimate is 1.5-fold (0.16 log units) above it, and the stated range covers the measured number.
By their numbers in this assay, from the lowest: compounds 3, 1 and 4 (each within the scatter of the next); then compound 2.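

In this assay nitro in place of hydrogen on the phenylsulfonyl group gives a 2.0-fold higher number from compound 3 to compound 4 (0.30 log units; within the scatter) and so stays within the usual scatter, even though three heavy atoms enter at this place, para to a large group. Among the compounds shown here, the only earlier change on this ring was fluoro on compound 1, which gave a 6.3-fold higher number from compound 1 to compound 2 (0.80 log units; beyond the scatter) and lay beyond the scatter, so a group at this place does not always carry a step of that size. Nothing measured here explains why these two steps differ in size.

The compounds shown leave open whether the nitro group would give a similar step on compound 1, which carries methyl in place of fluoro, and whether fluoro would do so on compound 3. They also leave open what an amine or a carboxylic acid would give at this same place.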